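The compounds below may be only part of what the source reports. "The series", "measured", "known", "first", "only" and "open" are said of these compounds alone.

For the measured compounds named here, in a functional assay on SK-OV-3 cells (Homo sapiens) for antiproliferative activity, read by MTT assay, with a stated time of 72 h (a lower number here means a stronger inhibitor, a higher number a weaker inhibitor), compound 2 `O=C(CCc1cccc2c1B(O)OC2)Nc1cccc(-c2ccc(C(F)(F)F)cc2)c1` gives 500 nM, the higher of the two numbers measured so far, while compound 1 `CSc1cccc(-c2cccc(NC(=O)CCc3cccc4c3B(O)OC4)c2)c1` gives 150 nM. Compound 3 `CC(=O)c1cccc(-c2cccc(NC(=O)CCc3cccc4c3B(O)OC4)c2)c1` differs from compound 2 in one place, with 3-acetylphenyl in place of 4-(trifluoromethyl)phenyl on an aromatic carbon. Going by the values given here, only one measured step bears on this change: a 3.3-fold higher number from compound 1 to compound 2 (0.52 log units; beyond the scatter). That modest step lies beyond the scatter and came from placing 4-(trifluoromethyl)phenyl where compound 1 carries 3-(methylsulfanyl)phenyl. The entering 3-acetylphenyl has a naming pattern closer to that group than to the one it replaces, so a partial return toward compound 1 at 150 nM seems likely, though a single step is thin support. The expected change is a 2.3-fold lower number from compound 2 to compound 3 (0.36 log units; beyond the scatter), toward a lower number. For compound 3 the estimate is 220 nM, with an expected range from 70 nM to 700 nM.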

Compound 3, half-maximal inhibitory concentration: 68 nM
The estimate for compound 3 lay 3.2-fold (0.51 log units) above the measured number; the measured number lies below the stated range.
By their numbers in this assay, from the lowest: compound 3; then compound 1; then compound 2.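

In this assay the 3-acetylphenyl group does more than undo the loss seen with 4-(trifluoromethyl)phenyl: the change brings a 7.4-fold lower number from compound 2 to compound 3 (0.87 log units; beyond the scatter) and takes the number past that of compound 1 rather than part of the way back to it. Acetyl in place of methylsulfanyl gives a 2.2-fold lower number from compound 1 to compound 3 (0.34 log units; beyond the scatter) and so shows that, even among the groups named at 3 on this phenyl ring, the number still moves with the group carried there. Nothing shown here gives a measured reason for these differences.

On these data alone, it remains open whether the gap between compound 2 and compound 3 follows the group or its position on the ring, as the two differ in both at once, and a 3-(trifluoromethyl)phenyl or 4-acetylphenyl group would separate these. As far as these compounds go, how an amine or a carboxylic acid at the place of the acetyl group would compare also stays open.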